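Adding a second methoxy to the limit-bound compound 2

The source may report more compounds than this note shows. Statements on the series, on what has been measured and on what is new or still open speak of the compounds shown alone.

In a functional assay on AGS cells (Homo sapiens) for antiproliferative activity, read by MTT assay, with a stated time of 48 h (a higher number here means a weaker inhibitor of growth, a lower number a stronger inhibitor of growth), compound 1 `COc1ccc(N(C)c2ncnc3c2ncn3Cc2ccc(OC)c(OC)c2)cc1`, which carries 3,4-dimethoxyphenyl, gives > 100000 nM, a limit and not a number. Compound 2 `COc1ccc(Cn2cnc3c(N(C)c4ccc(OC)cc4)nc(Cl)nc32)cc1`, which carries 4-methoxyphenyl, gives > 100000 nM, also a limit. Among the measured compounds shown here, both values therefore sit at the limit of > 100000 nM in this assay, at which 2 of the 2 values shown sit, so compound 2 has no exact position and no measured step is available. Compound 3 `COc1ccc(N(C)c2nc(Cl)nc3c2ncn3Cc2ccc(OC)c(OC)c2)cc1` follows from compound 2 by one change: methoxy in place of hydrogen on an aromatic carbon, turning 4-methoxyphenyl into 3,4-dimethoxyphenyl. Neither measured compound shows what this change does. The expected change, an at least 1.4-fold lower number from compound 2 to compound 3 (0.15 log units; that floor lies within the scatter), is small and towards stronger growth inhibition, and it may not exceed the scatter. For compound 3 the estimated value is 70000 nM, with an expected range from 15000 nM to 200000 nM.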

Compound 3, concentration for 50% growth inhibition: 56000 nM
The estimate for compound 3 lay 1.3-fold (0.10 log units) above the measured number; low and high end bracket the measured number.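

In this assay compound 3 gives 56000 nM, the first exact value in this small set, and it is the only compound shown that carries both chloro and 3,4-dimethoxyphenyl. Read against the limit of compound 2, the added methoxy on the aromatic carbon ortho to a methoxy group gives an at least 1.7-fold lower number from compound 2 to compound 3 (0.25 log units; that floor lies within the scatter). Read against the limit of compound 1, chloro in place of hydrogen on the core gives an at least 1.7-fold lower number from compound 1 to compound 3 (0.25 log units; that floor lies within the scatter).

The true size of each step stays unknown, because the values of compound 1 and compound 2 are limits and not numbers: the limit of > 100000 nM in this assay, at which 2 of the 3 values shown sit.

Also open, going by these compounds, is whether an amine or a longer chain in place of the chloro, or a carboxylic acid in place of the added methoxy, would shift the value of compound 3.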